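Bromo in place of hydrogen on compound 2

The compounds below may be only part of what the source reports. "The series", "measured", "known", "first", "only" and "open" are said of these compounds alone.

Compound 1 `COc1ccc(CN(C(=O)CSc2nc3cc(Cl)ccc3s2)c2cc(OC)c(OC)c(OC)c2)cc1O` gives 85 nM
Compound 2 `COc1cc(N(Cc2ccccc2)C(=O)CSc2nc3ccccc3s2)cc(OC)c1OC` gives 44300 nM

In a functional assay on MGC-803 cells (Homo sapiens) for antiproliferative activity, read by MTT assay, with a stated time of 48 h (on this read-out higher numbers stand for weaker inhibition and lower numbers for stronger inhibition), compound 2 stands highest of the two (44300 nM) and compound 1 gives 85 nM. The gap between these two compounds lies well beyond the scatter. Compound 3 `COc1cc(N(Cc2ccc(Br)cc2)C(=O)CSc2nc3ccccc3s2)cc(OC)c1OC` has not yet been measured. It differs from compound 2 by bromo in place of hydrogen on an aromatic carbon, para to a large group, turning benzyl to 4-bromobenzyl (bromo in place of hydrogen on an aromatic carbon). Among the compounds with values here, no measured step isolates this change, so only a modest move toward stronger inhibition is expected, close to the edge of the scatter (a 2.2-fold lower number from compound 2 to compound 3 (0.35 log units; beyond the scatter)). For compound 3 the estimated value is 20000 nM (range 4000 nM to 60000 nM).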

Compound 3, half-maximal inhibitory concentration: 48100 nM
For compound 3 the middle estimate is 2.4-fold (0.38 log units) below the measured one; measured number inside the range.
By their numbers in this assay, from the lowest: compound 1; then compounds 2 and 3 (each within the scatter of the next).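

In this assay, bromo in place of hydrogen on an aromatic carbon, para to a large group, gives a 1.1-fold higher number from compound 2 to compound 3 (0.04 log units; within the scatter), so benzyl and 4-bromobenzyl cannot be told apart on this read-out. Within the data shown here, this is the first measured step at this position, and it shows that this one added bromine atom leaves the number of compound 2 within the scatter. Nothing available explains this result.

The compounds shown leave open whether a different group at this place, such as an amine or a carboxylic acid, would also read like hydrogen. They also leave open whether bromo would behave the same way on the core of compound 1.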